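The compounds below may be only part of what the source reports. "The series", "measured", "known", "first", "only" and "open" are said of these compounds alone.

Among the measured compounds shown here, in a functional assay on A549 cells (Homo sapiens) for inhibition, read by MTT assay, with a stated time of 48 h (a lower number here means a stronger inhibitor, a higher number a weaker inhibitor), compound 3 (`Cc1nc(N(C)c2ccc(OCC[Se]C#N)cc2)c2ccccc2n1`) gives 893 nM, the highest of the three numbers measured so far. Compound 1 (`COc1ccc(N(C)c2nc(C)nc3ccccc23)cc1C(=O)OCCCC[Se]C#N`) gives 155 nM and compound 2 (`COc1ccc(N(C)c2nc(C)nc3ccccc23)cc1OCC[Se]C#N`) gives 13 nM. The change leading to compound 4 (`COc1ccc(N(C)c2nc(C)nc3ccccc23)cc1`) is a hydrogen atom in place of a group of 4 heavy atoms (2 carbon, 1 nitrogen, 1 selenium; no ring), on a saturated chain carbon bound to an oxygen on an aromatic ring. This removes the selenium from the molecule and leaves a methoxy group on the aromatic ring, a group that compound 1 and compound 2 also carry and compound 3 lacks.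

For the measured compounds named here, no measured step makes this exact change. The closest is a 12-fold lower number from compound 1 to compound 2 (1.08 log units; beyond the scatter), where a smaller group replaces a larger one on an aromatic carbon and the number falls by a large margin. That step is only indirect evidence, since it takes place at a different site and both of its compounds keep the selenium. Even so, compound 2 at 13 nM suggests that compounds with the methoxy group can reach low numbers, and the data do not show how much the selenium-bearing chain itself contributes.

A large step toward a lower number is therefore expected, and the estimated change is a 74-fold lower number from compound 3 to compound 4 (1.87 log units; beyond the scatter). For compound 4 the estimated value is 12 nM, with an expected range from 2 nM to 100 nM.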

Compound 4, half-maximal inhibitory concentration: 3 nM
For compound 4 the middle estimate is 4.0-fold (0.60 log units) above the measured one, within the range that was stated.
By their numbers in this assay, from the lowest: compound 4; then compound 2; then compound 1; then compound 3.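

In this assay, a low number does not depend on selenium: removing the selenium-bearing group gives a 300-fold lower number from compound 3 to compound 4 (2.47 log units; beyond the scatter) and leaves only a methoxy group, the largest step among these compounds. The other two selenium compounds point the same way, with a 4.3-fold lower number from compound 2 to compound 4 (0.64 log units; beyond the scatter) and a 52-fold lower number from compound 1 to compound 4 (1.71 log units; beyond the scatter) when their larger groups on the aromatic carbon give way to hydrogen, so compound 4 is the strongest inhibitor of the four and none of the selenium compounds goes against this. The size of the gain nevertheless varies widely, being modest from compound 2 but large from compound 1 and compound 3, so the cost of carrying a selenium-bearing group differs from one compound to another.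

Nothing shown here explains these steps.

The compounds shown leave open whether the small methoxy group is itself favoured on this saturated chain carbon bound to an oxygen on an aromatic ring, or whether an ethyl group or a longer chain without selenium would do as well. They also leave open how an amine or a carboxylic acid at the end of such a chain would compare.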